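The source may report more compounds than this note shows. Statements on the series, on what has been measured and on what is new or still open speak of the compounds shown alone.

Compound 2 `Cc1ccc2oc(=O)c(-c3ccc(Cl)nn3)cc2c1` gives 13500 nM in an assay on cells for inhibition of Amine oxidase [flavin-containing] B (Homo sapiens), read by fluorescence and Amplex Red, with a stated time of 15 min; on this read-out lower numbers stand for stronger inhibition and higher numbers for weaker inhibition; among the three measured compounds it stands furthest from compound 1 and alongside compound 3. Compound 1 `Cc1ccc2oc(=O)c(-c3ccc(Br)nn3)cc2c1` gives 2160 nM, and compound 3 `COc1ccc2oc(=O)c(-c3ccc(Cl)nn3)cc2c1` gives 8800 nM; the step of a 6.3-fold higher number from compound 1 to compound 2 (0.80 log units; beyond the scatter) lies beyond the scatter, whereas a 1.5-fold lower number from compound 2 to compound 3 (0.19 log units; within the scatter) lies within it. Compound 4 `COc1ccc(-c2cc3cc(C)ccc3oc2=O)nn1` differs from compound 2 by methoxy in place of chloro on an aromatic carbon, placed next to the ring nitrogen and para to a large group. Among the compounds with values here, no measured step swaps a halogen for a methoxy, though the step of a 6.3-fold higher number from compound 1 to compound 2 (0.80 log units; beyond the scatter) shows this position answers strongly to small changes. Compound 4 is therefore expected to give about 15000 nM, between 4000 nM and 60000 nM. The step of a 1.1-fold higher number from compound 2 to compound 4 (0.05 log units; within the scatter) is expected to be small, with wide uncertainty.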

Compound 4, half-maximal inhibitory concentration: 17600 nM
Beside the measured number, compound 4's estimate is 1.2-fold (0.07 log units) below it, and the stated range covers the measured number.
By their numbers in this assay, from the lowest: compound 1; then compounds 3, 2 and 4 (each within the scatter of the next).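

In this assay, methoxy in place of chloro on this aromatic carbon gives a step within the scatter, a 1.3-fold higher number from compound 2 to compound 4 (0.12 log units; within the scatter), so the two groups cannot be told apart here. Against bromo, the same methoxy gives an 8.1-fold higher number from compound 1 to compound 4 (0.91 log units; beyond the scatter), beyond the scatter, so bromo stands apart from both chloro and methoxy, and a split between halogen and non-halogen does not describe this position. Nothing shown gives a reason for bromo's separate place. Still open, on these data alone, is how iodo or an amine would compare at this position. Also open, as far as these compounds go, is whether bromo keeps its lead with the methoxy of compound 3 in place of the methyl on the core.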